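The source may hold more compounds than are shown below. What is called first, only, known or untested is meant among the compounds shown, and "the series" means these compounds.

Working notes on the ester series.

Compound 2 `CC(=O)OCCCOC1(c2ccc(Cl)cc2)c2ccccc2C(=O)N1Cc1ccccc1` is the acetate of the chain; in a functional assay on HCT-116 cells (Homo sapiens) for inhibition, read by fluorescence, with a stated time of 48 h (a higher number here means a weaker inhibitor of growth, a lower number a stronger inhibitor of growth), compound 2 gives 50000 nM. Compound 1 `N[C@H](C(=O)OCCCOC1(c2ccc(Cl)cc2)c2ccccc2C(=O)N1Cc1ccccc1)c1ccccc1` differs from it only by amino(phenyl)methyl in place of methyl on a carbonyl carbon. In this assay compound 1 gives 14000 nM, so the change makes the step of a 3.6-fold lower number from compound 2 to compound 1 (0.55 log units; beyond the scatter).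

Compound 3 `CC(=O)OCC(C)(C)COC1(c2ccc(Cl)cc2)c2ccccc2C(=O)N1Cc1ccc(Cl)cc1` carries the same acetyl ester on another core; the difference between the core of compound 3 and the core of compound 2 is not broken down here. In this assay compound 3 gives 35000 nM, a value within the scatter of that of compound 2 and higher than that of compound 1.

Compound 4 `CC(C)(COC(=O)[C@@H](N)c1ccccc1)COC1(c2ccc(Cl)cc2)c2ccccc2C(=O)N1Cc1ccc(Cl)cc1` has not been measured. It differs from compound 3 by amino(phenyl)methyl in place of methyl on a carbonyl carbon, the same change as that between compound 2 and compound 1, at a place described in identical words. With one measured instance only, the expectation for compound 4 rests on the step of a 3.6-fold lower number from compound 2 to compound 1 (0.55 log units; beyond the scatter) being carried over to the core of compound 3. On that basis the step from compound 3 to compound 4 in this assay is expected to be a 3.5-fold lower number from compound 3 to compound 4 (0.54 log units; beyond the scatter), roughly matching the earlier one. Compound 4 is therefore estimated at 10000 nM in this assay. For compound 4 the expected range runs from 4000 nM to 25000 nM, a deliberately wide range.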

Compound 4, concentration for 50% growth inhibition: 8000 nM
For compound 4 the middle estimate is 1.3-fold (0.10 log units) above the measured one; low and high end bracket the measured number.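

In this assay, placing amino(phenyl)methyl in place of methyl on the carbonyl carbon gives a 4.4-fold lower number from compound 3 to compound 4 (0.64 log units; beyond the scatter), and set beside the earlier step the two agree: the same change on two cores in this assay, a 3.6-fold lower number (0.55 log units; beyond the scatter) from compound 2 to compound 1 and a 4.4-fold lower number (0.64 log units; beyond the scatter) from compound 3 to compound 4, 1.2-fold (0.09 log units) apart, within the scatter of two such steps. Within these two pairs, then, the change carries over from the core of compound 2 to the core of compound 3 with its size preserved, so the step seen on one core served as a fair guide to the step on the other. This rests on two pairs and a single read-out; it does not establish that the step would hold on any other core, and it gives no explanation of why the step occurs.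

The compounds shown leave open which part of the entering group accounts for the step, since the amine and the phenyl ring always enter together; an aminomethyl group without the phenyl ring, or a benzyl group without the amine, would separate the two. Also open, on these data alone, are the mirror-image form of the amino(phenyl)methyl ester and the effect of a longer chain between the ester oxygen and the core.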